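Moving the Fluorine on the Benzamide Ring

This account rests on a few compounds, and the source may have more. Where it says the series, first, only, none or still open, it means among the compounds named here.

Measured compounds:
compound 1, `CN1CCN(c2ccc(Nc3nc(-c4cccc(NC(=O)c5ccccc5)c4)sc3C(=O)O)cc2)CC1`: 11.9%
compound 2, `CN1CCN(c2ccc(Nc3nc(-c4cccc(NC(=O)c5cccc(F)c5)c4)sc3C(=O)O)cc2)CC1`: 76.3%

In a functional assay on Raji cells (Homo sapiens) for antiproliferative activity, read by CCK-8 assay, with a stated time of 72 h, tested at 40 uM (on this read-out higher numbers stand for more inhibition at the one concentration tested (going by the name of the read-out) and lower numbers for less inhibition), compound 1 gives 11.9% and compound 2 gives 76.3%. For the measured compounds named here, compound 2 stands highest of the two measured numbers; its only neighbour is compound 1, and the step of a number 64.4 percentage points higher from compound 1 to compound 2 (beyond the scatter) lies well beyond the scatter.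

Compound 3, `CN1CCN(c2ccc(Nc3nc(-c4cccc(NC(=O)c5ccccc5F)c4)sc3C(=O)O)cc2)CC1`, has not been measured yet. It differs from compound 2 in one place: 2-fluorophenyl in place of 3-fluorophenyl on a carbonyl carbon. The fluorine stays, but the ring that carries it is exchanged, from 3-fluorophenyl to 2-fluorophenyl on the carbonyl carbon.

Going by the values given here, only one measured step exists, a number 64.4 percentage points higher from compound 1 to compound 2 (beyond the scatter), and it shows that placing a fluorine on the ring to give 3-fluorophenyl raised inhibition greatly. Among the compounds with values here, no measured pair shows what happens when the fluorine is instead placed to give 2-fluorophenyl, so the direction of the step of a number 31.3 percentage points lower from compound 2 to compound 3 (beyond the scatter) is expected with little confidence and is set as a modest drop. For compound 3 the estimate is 45%, with an expected range from 10% to 80%.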

Compound 3, a percentage reported as inhibition, at one concentration (the size of the read-out at that concentration, not a potency): 86.9%
For compound 3 the middle estimate is 41.9 percentage points below the measured one; the measured number lies above the stated range.
By their numbers in this assay, from the lowest: compound 1; then compound 2; then compound 3.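

Moving the fluorine does not cost activity in this assay, since the change to 2-fluorophenyl on the carbonyl carbon gives a number 10.6 percentage points higher from compound 2 to compound 3 (beyond the scatter) even though the two compounds contain exactly the same atoms. Read from the unsubstituted benzamide, the step of a number 75 percentage points higher from compound 1 to compound 3 (beyond the scatter) stands as a second large rise alongside a number 64.4 percentage points higher from compound 1 to compound 2 (beyond the scatter), so among these three compounds the gain from fluoro in place of hydrogen is not tied to 3-fluorophenyl alone. Nothing available here accounts for the gain or for the difference between the two fluorinated rings.

From the compounds shown here alone, it remains open whether the rise belongs to fluorine itself or would also come with another group on this ring, such as a chlorine atom, a methoxy group or a trifluoromethyl group, and whether 4-fluorophenyl or 2,6-difluorophenyl on the same carbonyl carbon would extend the trend or break it. A reading at a single concentration also leaves open how the potencies of compound 2 and compound 3 compare, which only a full concentration series could settle.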